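A few compounds are considered here, and "the series" means these few. Any claim that something is new, unique, unknown or untested is made for them only; others in the source may bear on it.

Within the data shown here, compound 1 `CCc1nc(-c2ccc(OC(F)(F)F)cc2OC)c(CC)nc1NC(CC)CC` is one of three compounds measured in an assay on IMR-32 cells for displacement of a labelled ligand from corticotropin-releasing factor receptor 1 (Homo sapiens), read by scintillation counting, with a stated time of 2 h; a lower number here means a stronger inhibitor, a higher number a weaker inhibitor. Among those three numbers compound 1 gives 7.2 nM, the second highest. Its nearest neighbour is compound 3 `CCc1nc(-c2ccc(OC(F)(F)F)cc2OC)c(OC)nc1NC(CC)CC`, which in this assay gives 6.1 nM; the step from compound 1 to compound 3 is a 1.2-fold lower number from compound 1 to compound 3 (0.07 log units; within the scatter), for methoxy in place of ethyl on an aromatic carbon. The furthest is compound 2 `CCc1nc(-c2ccc(OC)cc2O)c(CC)nc1NC(CC)CC`, which differs from compound 1 in two places; in this assay compound 2 gives 1180 nM.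

Compound 4 `CCOc1ccc(-c2nc(CC)c(NC(CC)CC)nc2CC)c(OC)c1` has not yet been measured. Against compound 1 the change is ethyl in place of trifluoromethyl on an oxygen on an aromatic ring; cut one bond further out it reads trifluoromethoxy to ethoxy. Among the measured compounds shown here, none of the measured steps touches this oxygen: the single step from compound 1 to compound 3 alters a group on the shared core, and compound 2 carries two changes at once, so its value and that of compound 1 can only be set side by side. For the measured compounds named here, there is thus no direct precedent in this assay, and the expected step is a modest rise in the number, a 3.5-fold higher number from compound 1 to compound 4 (0.54 log units; beyond the scatter). Compound 4 is accordingly estimated at 25 nM, with a range from 6 nM to 100 nM.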

Compound 4, inhibition constant: 7.8 nM
Compound 4: the middle estimate sits 3.2-fold (0.51 log units) above what was measured; the range from low to high includes it.
By their numbers in this assay, from the lowest: compounds 3, 1 and 4 (each within the scatter of the next); then compound 2.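

In this assay, among these compounds, ethyl in place of trifluoromethyl on an oxygen on an aromatic ring gives a 1.1-fold higher number from compound 1 to compound 4 (0.03 log units; within the scatter) and is the first change at this oxygen that can be read directly. The earlier step from the measured compounds concerned only a group on the shared core, so it said nothing about this position, whereas this pair shows that trifluoromethoxy and ethoxy cannot be told apart here. At this oxygen, then, the fluorine atoms of compound 1 are not required for a number of this size, since compound 4 carries none and still reads alongside compound 1.

Going by these compounds, it remains open whether the same holds for a longer chain such as butyl on this oxygen, for an amine in its place, or for ethoxy combined with methoxy in place of ethyl on the core. The data at hand hold no measurement that would explain why these two groups read alike.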